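A few compounds are considered here, and "the series" means these few. Any claim that something is new, unique, unknown or untested is made for them only; others in the source may bear on it.

The measured compounds in a functional assay, read by spectrophotometry, with a stated time of 15 min; on this read-out higher numbers stand for weaker inhibition and lower numbers for stronger inhibition:
compound 1, `Cc1nc2c3ccccc3ccc2c2nc3c(ccc4ccccc43)c(-c3cccnc3)c12`: 63.6 ug/mL
compound 2, `Cc1nc2c3ccccc3ccc2c2nc3c(ccc4ccccc43)c(-c3ccc(O)cc3)c12`: 44.1 ug/mL

Within the data shown here, compound 2 stands at the low end of these two numbers, but the only measured step, a 1.4-fold lower number from compound 1 to compound 2 (0.16 log units; within the scatter), lies within the scatter, so the two compounds cannot be separated on this read-out.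

Compound 3, `Cc1nc2c3ccccc3ccc2c2nc3c(ccc4ccccc43)c(-c3cc(O)nc4ccccc34)c12`, is not yet measured. It differs from compound 2 by 2-hydroxyquinolin-4-yl in place of 4-hydroxyphenyl on an aromatic carbon. Among the measured compounds shown here, the one step that bears on this change is the exchange of the group at the same aromatic carbon between compound 1 and compound 2, a 1.4-fold lower number from compound 1 to compound 2 (0.16 log units; within the scatter), which did not move the number beyond the scatter. On that single precedent, the step expected for compound 3 is none beyond the scatter, namely a 1.0-fold higher number from compound 2 to compound 3 (0.01 log units; within the scatter).

For compound 3 the estimated number in this assay is 45 ug/mL, with a range from 20 ug/mL to 100 ug/mL.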

Compound 3, half-maximal inhibitory concentration: 44.8 ug/mL
Compound 3: middle estimate off by 1.0-fold (0.00 log units), on the high side; the range from low to high includes it.
By their numbers in this assay, from the lowest: compounds 2, 3 and 1 (each within the scatter of the next).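

Compound 3 carries 2-hydroxyquinolin-4-yl, which adds a second six-membered aromatic ring at the carbon opposite the ring nitrogen, yet in this assay it cannot be separated from either of the other compounds (a 1.0-fold higher number from compound 2 to compound 3 (0.01 log units; within the scatter); a 1.4-fold lower number from compound 1 to compound 3 (0.15 log units; within the scatter)). Pyridin-3-yl, 4-hydroxyphenyl and 2-hydroxyquinolin-4-yl at this carbon thus all lie within the scatter of one another, so the larger fused group gives no measurable step on this read-out. No measurement at hand explains this result.

As far as these compounds go, all three compounds carry aromatic ring groups at this carbon, so it remains open whether an amine, a carboxylic acid or a longer alkyl chain there would give a step beyond the scatter. No plain quinolin-4-yl group appears among them, which also leaves open what the hydroxyl contributes.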